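Removing the Chloro Group from Compound 3

This account rests on a few compounds, and the source may have more. Where it says the series, first, only, none or still open, it means among the compounds named here.

Measured so far in a functional assay on SiHa cells (Homo sapiens) for inhibition, read by CCK-8 assay, with a stated time of 72 h, tested at 1 uM (a lower number here means less inhibition of growth, a higher number more inhibition of growth at the concentration tested), by compound:
compound 1 `CN(C)C(=O)c1cc2cnc(Nc3ccc(N)cn3)nc2n1C1CCCC1` gives -21.2%
compound 2 `CN(C)C(=O)c1cc2cnc(Nc3ccc(NC(=O)C4(C(=O)Nc5cccc(O)c5)CC4)cc3)nc2n1C1CCCC1` gives -19.8%
compound 3 `CN(C)C(=O)c1cc2cnc(Nc3ccc(NC(=O)C4(C(=O)Nc5cccc(Cl)c5)CC4)cc3)nc2n1C1CCCC1` gives 16.2%

Compound 3 holds the highest number of the three, and the gaps to compound 1 and compound 2 both lie beyond the scatter. The compound now awaiting measurement, compound 4 `CN(C)C(=O)c1cc2cnc(Nc3ccc(NC(=O)C4(C(=O)Nc5ccccc5)CC4)cc3)nc2n1C1CCCC1`, differs from compound 3 in one place: hydrogen in place of chloro on an aromatic carbon. This is hydrogen in place of chloro on an aromatic carbon, meta to a large group.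

Among the measured compounds shown here, one measured step bears on this change, and it involves the same aromatic carbon. In that large step, a number 36 percentage points higher from compound 2 to compound 3 (beyond the scatter), chloro takes the place of hydroxy. For the measured compounds named here, no compound carrying hydrogen there has been measured, so that step gives only a loose guide. Compound 4 is expected to fall between compound 2 at -19.8% and compound 3 at 16.2%. A moderate drop is therefore expected, with an estimated a number 16.2 percentage points lower from compound 3 to compound 4 (beyond the scatter). For compound 4 the estimated value is 0%, within an expected range from -20% to 20%.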

Compound 4, percent growth inhibition at one concentration: 58%
For compound 4 the middle estimate is 58 percentage points below the measured one; measured number outside the range, above it.
By their numbers in this assay, from the lowest: compounds 1 and 2 (each within the scatter of the next); then compound 3; then compound 4.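

In this assay, hydrogen in place of chloro on this aromatic carbon gives a number 41.8 percentage points higher from compound 3 to compound 4 (beyond the scatter), so removing the chloro raises growth inhibition rather than lowering it. Hydrogen in place of hydroxy on the same carbon gives a number 77.8 percentage points higher from compound 2 to compound 4 (beyond the scatter), which shows that chloro ranks above hydroxy here, yet both stand below hydrogen, and neither group is needed for the effect seen with the phenylcarbamoyl compound. The compounds shown offer no measurement that could explain why hydrogen gives the highest number of the three groups on this carbon.

Going by these compounds, it remains open whether a smaller halogen such as fluoro, or a methyl, methoxy, amine or carboxylic acid group, on this carbon would also stand below hydrogen. On these data alone, it also remains open whether any group on the other carbons of this ring would give the same result.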